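This account rests on a few compounds, and the source may have more. Where it says the series, first, only, none or still open, it means among the compounds named here.

Compound 1 `COc1ccc(-c2nc(N)c3nc(-c4ccccc4)sc3n2)cc1` is tested in a functional assay on CHO cells for antagonist activity at adenosine receptor A2b (Homo sapiens), read by cAMP accumulation, with a stated time of 10 min; on this read-out lower numbers stand for stronger inhibition and higher numbers for weaker inhibition. In this assay compound 1 reaches only a limit, > 30000 nM, not a measured number. Compound 2 `Nc1nc(-c2ccco2)nc2sc(-c3ccccc3)nc12` likewise stops at a limit of > 30000 nM. Compound 3 `Cc1ccc(-c2nc(N)c3nc(-c4ccccc4)sc3n2)o1` also stops at a limit of > 30000 nM. The steps between them, a step that the two limits leave unreadable from compound 1 to compound 2, a step that the two limits leave unreadable from compound 1 to compound 3 and a step that the two limits leave unreadable from compound 2 to compound 3, therefore cannot be read, as all three values rest at the limit of > 30000 nM in this assay, at which 3 of the 3 values shown sit. Compound 4 `COc1ccc(-c2nc(N)c3nc(-c4ccco4)sc3n2)cc1` differs from compound 1 by furan-2-yl in place of phenyl on an aromatic carbon, a change on the five-membered ring of the shared core. Among the measured compounds shown here, no measured step resembles this change, so the expected size of a step that the limit leaves unreadable from compound 1 to compound 4 is a guess. Compound 4 is estimated at 40000 nM, within 5000 nM to 300000 nM, most likely again a limit.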

Compound 4, half-maximal inhibitory concentration: > 30000 nM
Compound 4: a limit, no number; the forecaster's own chance of this, stated with the estimate: 75%; the middle value does not contradict the limit.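

Compound 4 gives only a limit of > 30000 nM and not a number, so the step from compound 1 to compound 4 cannot be read. Which change to the shared core would give a measured number stays open, because every value shown rests at the same point: the limit of > 30000 nM in this assay, at which 4 of the 4 values shown sit.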